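A few compounds are considered here, and "the series" means these few. Any claim that something is new, unique, unknown or untested is made for them only; others in the source may bear on it.

Compound 1, `CO[C@@H]1[C@H](N(C)c2ncc(-c3c[nH]c4ccccc34)s2)C[C@H]2O[C@]1(C)n1c3ccccc3c3c4c(c5c6cc(Cl)ccc6n2c5c31)C(=O)NC4`: > 10000 nM
Compound 2, `CO[C@@H]1[C@H](N(C)c2ncc(-c3c[nH]c4ccc(Cl)cc34)s2)C[C@H]2O[C@]1(C)n1c3ccccc3c3c4c(c5c6cc(Cl)ccc6n2c5c31)C(=O)NC4`: > 10000 nM
Compound 3, `CO[C@@H]1[C@H](N(C)c2ncc(-c3c[nH]c4ccc(Br)cc34)s2)C[C@H]2O[C@]1(C)n1c3ccccc3c3c4c(c5c6cc(Cl)ccc6n2c5c31)C(=O)NC4`: > 10000 nM

In a functional assay on K562 cells (Homo sapiens) for antiproliferative activity, read by CellTiter-Glo, with a stated time of 72 h (a lower number here means a stronger inhibitor, a higher number a weaker inhibitor), compound 1 gives > 10000 nM, and this is a limit of the assay, not a number. Compound 2 likewise gives > 10000 nM, again a limit. Compound 3 gives > 10000 nM, also a limit. The steps between them are therefore a step that the two limits leave unreadable from compound 1 to compound 2, a step that the two limits leave unreadable from compound 1 to compound 3 and a step that the two limits leave unreadable from compound 2 to compound 3; all three values sit at the limit of > 10000 nM in this assay, at which 3 of the 3 values shown sit, so none of the steps can be sized.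

Compound 4, `CO[C@@H]1[C@H](N(C)c2ncc(-c3c[nH]c4ccccc34)s2)C[C@H]2O[C@]1(C)n1c3ccccc3c3c4c(c5c6cc(Br)ccc6n2c5c31)C(=O)NC4`, differs from compound 1 by bromo in place of chloro on an aromatic carbon. Going by the values given here, the only measured step of the same kind, bromo in place of chloro on an aromatic carbon, is the one from compound 2 to compound 3, where both ends rest at the limit and no size can be read, though that swap sits elsewhere in the molecule. Nothing measured here points to a change beyond the scatter in either direction, and the shared core is common to all three compounds that failed to reach a number.

Compound 4 is therefore expected to give about 15000 nM, with a range from 5000 nM to 50000 nM. That expectation amounts to a step that the limit leaves unreadable from compound 1 to compound 4, a step that would most likely stay hidden behind the same limit.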

Compound 4, half-maximal inhibitory concentration: > 10000 nM
Compound 4 was reported as a limit (the forecaster's own chance of this, stated with the estimate: 85%); the middle value lies beyond the limit too.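

No new step can be read: compound 1 and compound 4 are both reported only as limits, so the swap of chloro for bromo cannot be sized. How strongly compound 1, compound 2, compound 3 and compound 4 each act, and whether they differ at all, stays open, with every result resting at one value: the limit of > 10000 nM in this assay, at which 4 of the 4 values shown sit.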